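Swapping methyl for dimethylamino on the aromatic ring

The source may hold more compounds than are shown below. What is called first, only, known or untested is meant among the compounds shown, and "the series" means these compounds.

Compound 1 (`Cc1ccc([C@H](C(=O)N(C)C)N2C(=O)[C@@H](C3Cc4ccccc4C3)NC(=O)[C@H]2CC(C)C)cn1`): 2680 ng.h/mL
Compound 2 (`Cc1ccc([C@H](C(=O)N2CCCC2)N2C(=O)[C@@H](C3Cc4ccccc4C3)NC(=O)[C@H]2CC(C)C)cn1`): 920 ng.h/mL
Compound 3 (`CCC(CC)[C@@H]1C(=O)N[C@H](C2Cc3ccccc3C2)C(=O)N1[C@@H](C(=O)N(C)C)c1ccc(C)nc1`): 1810 ng.h/mL

In an ADME assay on the whole organism (plasma) for pharmacokinetics, with Rattus norvegicus as the target, at a dose of 5 mg/kg by the oral route (on this read-out higher numbers stand for higher exposure at the dose given and lower numbers for lower exposure), compound 1 sits at the upper end of these three numbers, a place it shares within the scatter with one other compound. Swapping isobutyl for pentan-3-yl gives a 1.5-fold lower number from compound 1 to compound 3 (0.17 log units; within the scatter). Swapping dimethylamino for pyrrolidin-1-yl on the carbonyl carbon gives a 2.9-fold lower number from compound 1 to compound 2 (0.46 log units; beyond the scatter).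

Compound 4 (`CC(C)C[C@@H]1C(=O)N[C@H](C2Cc3ccccc3C2)C(=O)N1[C@@H](C(=O)N(C)C)c1ccc(N(C)C)nc1`) is still unmeasured. Among the compounds with values here, it differs from the first compound at a single place (dimethylamino in place of methyl on an aromatic carbon), with dimethylamino in place of methyl on an aromatic carbon. Neither measured step touches that carbon, so they indicate only a plausible size. Within the data shown here, with compound 1 at the upper end, a lower number is expected, though no larger than those steps and possibly within the scatter. The expected change is a 1.9-fold lower number from compound 1 to compound 4 (0.28 log units; within the scatter). For compound 4 the estimated value is 1400 ng.h/mL, with an expected range from 500 ng.h/mL to 3500 ng.h/mL.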

Compound 4, area under the concentration-time curve: 135 ng.h/mL
The estimate for compound 4 lay 10-fold (1.02 log units) above the measured number, and the stated range ends above it.
By their numbers in this assay, from the lowest: compound 4; then compounds 2, 3 and 1 (each within the scatter of the next, the first and the last beyond it).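

On the six-membered aromatic ring, next to the ring nitrogen, dimethylamino in place of methyl gives a 20-fold lower number from compound 1 to compound 4 (1.30 log units; beyond the scatter) in this assay, a large step. The earlier changes, on the carbonyl carbon and the saturated ring carbon, moved this read-out far less, so among the three places changed, this aromatic carbon is the one where the choice of group counts most. Nothing measured here explains the drop.

At this carbon the compounds shown carry only methyl and dimethylamino, so it remains open whether the loss would also appear with a smaller amine such as methylamino, or with methoxy or a longer chain such as ethyl. As far as these compounds go, it is also open whether dimethylamino would have the same effect alongside the pentan-3-yl group of compound 3 or the pyrrolidin-1-yl group of compound 2.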